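Swapping the aryl group on the hydrazone arm

This account rests on a few compounds, and the source may have more. Where it says the series, first, only, none or still open, it means among the compounds named here.

Measured so far:
- compound 1, `CCCSc1nc(N/N=C/c2cccc(Cl)c2)c2nnn(Cc3ccccc3)c2n1`: in a functional assay on ECa-109 cells (Homo sapiens) for antiproliferative activity, read by MTT assay, with a stated time of 72 h (a lower number here means a stronger inhibitor, a higher number a weaker inhibitor), compound 1 gives > 64000 nM, which is a limit of the assay rather than a number.
- compound 2, `CCCSc1nc(N/N=C/c2c[nH]c3ccccc23)c2nnn(Cc3ccccc3)c2n1`: in this assay compound 2 gives 8690 nM.
- compound 3, `CCCSc1nc(N/N=C/c2ccc(N(C)C)cc2)c2nnn(Cc3ccccc3)c2n1`: in this assay compound 3 gives 20000 nM.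

Among the two compounds with a real number, compound 3 has the higher one, with compound 2 as its nearest neighbour: a 2.3-fold higher number from compound 2 to compound 3 (0.36 log units; beyond the scatter). Compound 1 sits at a limit (the limit of > 64000 nM in this assay, at which 1 of the 3 values shown sits), so the steps starting from it are only bounds: an at least 7.3-fold lower number from compound 1 to compound 2 (0.86 log units; beyond the scatter) and an at least 3.2-fold lower number from compound 1 to compound 3 (0.50 log units; beyond the scatter).

Compound 4, `CCCSc1nc(N/N=C/c2c(O)ccc3ccccc23)c2nnn(Cc3ccccc3)c2n1`, differs from compound 3 in one place: 2-hydroxynaphthalen-1-yl in place of 4-(dimethylamino)phenyl on a carbon with a double bond to nitrogen. For the measured compounds named here, no measured step makes exactly this change. The step from compound 2 to compound 3 is the closest guide, since there a fused two-ring group, 1H-indol-3-yl, gave the lower number and the single-ring 4-(dimethylamino)phenyl the higher one. The entering 2-hydroxynaphthalen-1-yl is again a fused two-ring group, and compound 4 is therefore expected to show a modest move to a lower number: a 2.5-fold lower number from compound 3 to compound 4 (0.40 log units; beyond the scatter). The estimate for compound 4 in this assay is 8000 nM, expected to fall between 2500 nM and 30000 nM.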

Compound 4, half-maximal inhibitory concentration: 9290 nM
The estimate for compound 4 lay 1.2-fold (0.06 log units) below the measured number; the range from low to high includes it.
By their numbers in this assay, from the lowest: compounds 2 and 4 (each within the scatter of the next); then compound 3. At a limit, above all of these: compound 1.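

Compound 4 gives the position a second fused two-ring group, and it again ends up with a lower number than the single-ring 4-(dimethylamino)phenyl, with a 2.2-fold lower number from compound 3 to compound 4 (0.33 log units; beyond the scatter) in this assay. The two fused groups cannot be told apart here, with a 1.1-fold higher number from compound 2 to compound 4 (0.03 log units; within the scatter), so this position accepts either 1H-indol-3-yl or 2-hydroxynaphthalen-1-yl, two different groups, with no measurable change in the read-out. Compound 1 sits at a limit, so an at least 6.8-fold lower number from compound 1 to compound 4 (0.83 log units; beyond the scatter) is only a bound, but it keeps both single-ring compounds on the weaker side of both fused ones, and how far the gap to 3-chlorophenyl really runs stays unknown: the limit of > 64000 nM in this assay, at which 1 of the 4 values shown sits.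

The compounds shown cannot say whether the second ring or the hydroxyl matters more, since a plain naphthalen-1-yl and a single-ring 2-hydroxyphenyl would pull those two features apart. They also leave open how the position responds to a group without an aromatic ring, such as cyclohexyl, and whether the same ranking holds once the propylthio chain or the benzyl group on the shared core is replaced.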